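A few compounds are considered here, and "the series" means these few. Any claim that something is new, unique, unknown or untested is made for them only; others in the source may bear on it.

Compound 1 `Cc1ccc(NC(=S)NC(=O)c2ccc(OCc3ccc(C(F)(F)F)cc3)cc2)cc1-c1nc2ccccc2[nH]1` stands second highest of the three numbers in a functional assay on MNK45 cells (Homo sapiens) for inhibition, read by MTT assay, with a stated time of 48 h (a higher number here means a weaker inhibitor, a lower number a stronger inhibitor), where compound 1 gives 10200 nM. Compound 3 `Cc1ccc(NC(=S)NC(=O)c2ccc(OCc3ccc(Cl)c(Cl)c3)cc2)cc1-c1nc2ccccc2[nH]1` gives 8410 nM, and a 1.2-fold lower number from compound 1 to compound 3 (0.08 log units; within the scatter). Compound 2 `Cc1ccc(NC(=S)NC(=O)c2ccc(OCc3cccc(F)c3)cc2)cc1-c1nc2ccccc2[nH]1` gives 86800 nM, and an 8.5-fold higher number from compound 1 to compound 2 (0.93 log units; beyond the scatter); likewise a 10-fold lower number from compound 2 to compound 3 (1.01 log units; beyond the scatter). Compound 4 `O=C(NC(=S)Nc1ccc(Cl)c(-c2nc3ccccc3[nH]2)c1)c1ccc(OCc2ccc(C(F)(F)F)cc2)cc1` differs from compound 1 by chloro in place of methyl on an aromatic carbon. Among the measured compounds shown here, every measured step changes the group on the saturated chain carbon bound to the oxygen on the aromatic ring; none touches the aromatic carbon ortho to the 1H-benzimidazol-2-yl group, so no measured step bears on this change. With nothing to lean on, no step beyond the scatter is expected in this assay in either direction. Compound 4 is therefore estimated at 10000 nM, with a range from 3000 nM to 35000 nM, which means an expected step of a 1.0-fold lower number from compound 1 to compound 4 (0.01 log units; within the scatter).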

Compound 4, half-maximal inhibitory concentration: 7830 nM
Compound 4: the middle estimate sits 1.3-fold (0.11 log units) above what was measured; the range from low to high includes it.
By their numbers in this assay, from the lowest: compounds 4, 3 and 1 (each within the scatter of the next); then compound 2.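

In this assay, among the compounds shown here, chloro in place of methyl on the aromatic carbon ortho to a 1H-benzimidazol-2-yl group gives a 1.3-fold lower number from compound 1 to compound 4 (0.11 log units; within the scatter), the first reading at a position no earlier step touched. With the 4-(trifluoromethyl)phenyl group held constant, this position therefore takes either group without a step beyond the scatter. No evidence is available that bears on this result. From the compounds shown here alone, what an amine, a methoxy group or a carboxylic acid would do on this aromatic carbon remains open. Going by these compounds, it also remains open whether chloro in place of methyl reads the same alongside the 3-fluorophenyl or 3,4-dichlorophenyl groups.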